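Ring-size change in a chloroquinoline purine series: cytotoxicity

This account rests on a few compounds, and the source may have more. Where it says the series, first, only, none or still open, it means among the compounds named here.

Compound 1 `Clc1ccc2c(NCCn3cnc4c(N5CCCCC5)nc(Cl)nc43)ccnc2c1`, compound 2 `Clc1ccc2c(NCCn3cnc4c(N5CCCCCC5)nc(Cl)nc43)ccnc2c1` and compound 3 `Clc1ccc2c(NCCCn3cnc4c(N5CCCCC5)nc(Cl)nc43)ccnc2c1` were tested in an ADME assay on Vero cells (Chlorocebus sabaeus) for cytotoxicity, read by neutral red uptake, with a stated time of 48 h; on this read-out lower numbers stand for stronger inhibition and higher numbers for weaker inhibition. For compound 1 the result is a limit of the assay, > 10700 nM. For compound 2 the result is likewise a limit, > 10400 nM. For compound 3 only a limit is reported as well, > 10400 nM. The change from compound 1 to compound 2 is azepan-1-yl in place of piperidin-1-yl on an aromatic carbon, and the corresponding step that the two limits leave unreadable from compound 1 to compound 2 cannot be sized, since both values are limits; see the limit of > 10400 nM in this assay, at which 2 of the 3 values shown sit, and (the limit of > 10700 nM in this assay, at which 1 of the 3 values shown sits). The difference between the cores of compound 1 and compound 3 is not broken down here.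

Compound 4 `Clc1ccc2c(NCCCn3cnc4c(N5CCCCCC5)nc(Cl)nc43)ccnc2c1` is not yet measured in this assay. It differs from compound 3 by azepan-1-yl in place of piperidin-1-yl on an aromatic carbon, the same change as that from compound 1 to compound 2. For compound 4 the expected step from compound 3 is a step that the limit leaves unreadable from compound 3 to compound 4, which rests on the unreadable step that the two limits leave unreadable from compound 1 to compound 2 and on the limit described in the limit of > 10400 nM in this assay, at which 2 of the 3 values shown sit. Compound 4 is therefore estimated at 15000 nM, with a range from 8000 nM to 40000 nM, and most likely the assay will again report only a limit.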

Compound 4, half-maximal inhibitory concentration: > 10100 nM
Compound 4: a limit, no number (the forecaster's own chance of this, stated with the estimate: 85%); the middle value is on the limit's open side.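

In this assay the result for compound 4 is a limit of the assay (> 10100 nM). Compound 3 also stands at a limit, so no step can be read between these two compounds, nor between compound 1 and compound 2. The compounds shown leave open whether azepan-1-yl in place of piperidin-1-yl shifts the read-out at all, and where any of the four compounds would reach half-maximal inhibition.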